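The compounds below may be only part of what the source reports. "The series", "measured", "known", "first", "only" and "open" are said of these compounds alone.

Measured compounds:
- compound 1, `CCOC(=O)c1cnnn1CCOCC1=NC(C)=C(C(=O)OC)C(c2ccccc2Cl)/C1=C(\O)OCC`: 100 nM
- compound 2, `CCO/C(O)=C1\C(COCCn2cc(N)n(C)c2=O)=NC(C)=C(C(=O)OC)C1c1ccccc1Cl`: 25.1 nM
- compound 3, `CCO/C(O)=C1\C(COCCn2nncc2C(N)=O)=NC(C)=C(C(=O)OC)C1c1ccccc1Cl`: 100 nM

Among the measured compounds shown here, in a functional assay (aorta) with Rattus norvegicus as the target (on this read-out higher numbers stand for weaker inhibition and lower numbers for stronger inhibition), compound 1 gives 100 nM, level with compound 3 and together with it the highest of the three numbers; the only step out of this pair is a 4.0-fold lower number from compound 1 to compound 2 (0.60 log units; beyond the scatter), a modest gain for compound 2. The reverse step, a 4.0-fold higher number from compound 2 to compound 3 (0.60 log units; beyond the scatter), shows the same gap seen from the other side, while no change at the digits printed from compound 1 to compound 3 (within the scatter) stays within the scatter.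

Compound 4, `CCO/C(O)=C1\C(COCCn2cc(N)nc2O)=NC(C)=C(C(=O)OC)C1c1ccccc1Cl`, is compound 1 with 4-amino-2-hydroxy-1H-imidazol-1-yl in place of 5-(ethoxycarbonyl)-1H-1,2,3-triazol-1-yl on a saturated chain carbon, two bonds along the chain from an oxygen on a saturated carbon. The change that bears on it most is the one behind a 4.0-fold lower number from compound 1 to compound 2 (0.60 log units; beyond the scatter), since compound 4 and compound 2 both carry an amino-substituted five-membered aromatic ring with two hetero atoms in place of the triazolyl ring of compound 1. For the measured compounds named here, on that basis a modest lowering in this assay is expected for compound 4, in the direction of compound 2, though the hydroxy group has no measured precedent here. The estimate for compound 4 is 35 nM, between 14 nM and 120 nM, which means an expected step of a 2.9-fold lower number from compound 1 to compound 4 (0.46 log units; beyond the scatter).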

Compound 4, half-maximal inhibitory concentration: 31.6 nM
The estimate for compound 4 lay 1.1-fold (0.04 log units) above the measured number, within the range that was stated.
By their numbers in this assay, from the lowest: compounds 2 and 4 (each within the scatter of the next); then compounds 1 and 3 (each within the scatter of the next).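

At this position, on a saturated chain carbon, two bonds along the chain from an oxygen on a saturated carbon, 4-amino-2-hydroxy-1H-imidazol-1-yl gives in this assay a 3.2-fold lower number from compound 1 to compound 4 (0.50 log units; beyond the scatter) and a 3.2-fold lower number from compound 3 to compound 4 (0.50 log units; beyond the scatter), so it stands apart from both the ethoxycarbonyl and the carbamoyl triazolyl groups. With a 1.3-fold higher number from compound 2 to compound 4 (0.10 log units; within the scatter), it cannot be told apart from the group in compound 2, so among these four compounds both rings with two hetero atoms give lower numbers than both rings with three, and none goes against this. Nothing measured here accounts for the difference.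

On these data alone, whether the lower numbers go with the amino group, the hydroxy group or the ring itself remains open. Among the compounds shown here, an imidazol-1-yl ring carrying only one of these groups, or a chain longer than the 2-substituted ethyl, would bear on this.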